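Aryl in place of bromo on compound 3

A few compounds are considered here, and "the series" means these few. Any claim that something is new, unique, unknown or untested is made for them only; others in the source may bear on it.

Compound 3 `O=C(CCc1cccc2c1B(O)OC2)Nc1cccc(Br)c1` stands lowest of the two numbers shown in a functional assay on SK-OV-3 cells (Homo sapiens) for antiproliferative activity, read by MTT assay, with a stated time of 72 h; on this read-out higher numbers stand for weaker inhibition and lower numbers for stronger inhibition: compound 3 gives 540 nM. Compound 2 `O=C(CCc1cccc2c1B(O)OC2)Nc1ccc(I)cc1` gives 51000 nM. Compound 1 `O=C(CCc1cccc2c1B(O)OC2)Nc1nccs1` reaches only the limit > 100000 nM, so no number stands for it (the limit of > 100000 nM in this assay, at which 1 of the 3 values shown sits). The two measured steps leading to compound 3 were large: an at least 180-fold lower number from compound 1 to compound 3 (2.26 log units; beyond the scatter) and a 94-fold lower number from compound 2 to compound 3 (1.98 log units; beyond the scatter); the step of an at least 1.9-fold lower number from compound 1 to compound 2 (0.29 log units; that floor lies within the scatter) sits at a floor inside the scatter. Compound 4 `CC(=O)c1cccc(-c2cccc(NC(=O)CCc3cccc4c3B(O)OC4)c2)c1` differs from compound 3 as follows: 3-acetylphenyl in place of bromo on an aromatic carbon. Within the data shown here, none of the measured steps replaces a halogen on the ring with a second aromatic ring; each swaps the whole aryl on the amide-type nitrogen, so they show only that the group on that ring governs this read-out strongly, without settling the direction here. A moderate change is therefore expected, direction open, with a wide range: the estimated step is a 2.8-fold higher number from compound 3 to compound 4 (0.44 log units; beyond the scatter). Compound 4 is estimated at 1500 nM, between 200 nM and 12000 nM.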

Compound 4, half-maximal inhibitory concentration: 68 nM
Compound 4: the middle estimate sits 22-fold (1.34 log units) above what was measured; measured number outside the range, below it.
By their numbers in this assay, from the lowest: compound 4; then compound 3; then compound 2. At a limit, above all of these: compound 1.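

In this assay the exchange of bromo for 3-acetylphenyl gives a 7.9-fold lower number from compound 3 to compound 4 (0.90 log units; beyond the scatter) and so settles the direction at this aromatic carbon, which the earlier swaps of the whole aryl on the amide-type nitrogen could not do. The halogen is not needed here for a low number, since compound 4 carries an added six-membered aromatic ring of carbon only in its place and still stands lower than compound 3. This single step is modest next to those earlier swaps, yet it shows that this position can take a much larger group with a gain on this read-out.

The compounds shown do not separate the added ring from the acetyl group on it. A plain phenyl, or a phenyl bearing an amine or a carboxylic acid in place of acetyl, would tell these apart. No measurement shown here gives a cause for this step.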